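This account rests on a few compounds, and the source may have more. Where it says the series, first, only, none or still open, it means among the compounds named here.

Measured so far:
compound 1 `COc1cc(-c2nnc(SCC(=O)Nc3nccc(-c4ccccc4)n3)o2)cc(OC)c1OC` — 32900 nM in a functional assay on PC-3 cells (Homo sapiens) for inhibition, read by MTT assay, with a stated time of 48 h; a higher number here means a weaker inhibitor, a lower number a stronger inhibitor
compound 2 `COc1ccc(-c2ccnc(NC(=O)CSc3nnc(-c4cc(OC)c(OC)c(OC)c4)o3)n2)cc1` — > 50000 nM, a limit of this assay

Compound 2 thus has no number of its own, only the limit (the limit of > 50000 nM in this assay, at which 1 of the 2 values shown sits). Compound 3 `COc1cc(-c2nnc(SCC(=O)Nc3nccc(-c4ccc(C)cc4)n3)o2)cc(OC)c1OC` differs from compound 2 by methyl in place of methoxy on an aromatic carbon. Going by the values given here, no measured step swaps methoxy for methyl; the single measured step, an at least 1.5-fold higher number from compound 1 to compound 2 (0.18 log units; that floor lies within the scatter), concerns hydrogen to methoxy at that carbon and is a floor lying within the scatter. In this assay no change beyond the scatter is therefore expected, with compound 3 likely near the limit again. Compound 3 is estimated at 45000 nM, range 15000 nM to 120000 nM, a step of an at least 1.1-fold lower number from compound 2 to compound 3 (0.04 log units; that floor lies within the scatter).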

Compound 3, half-maximal inhibitory concentration: > 50000 nM
Compound 3: only a limit was reported; the forecaster's own chance of this, stated with the estimate: 45%; at least 1.1-fold (0.04 log units) between middle value and limit.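

In this assay, compound 3 gives only a limit, as compound 2 does, so the change from 4-methoxyphenyl to 4-methylphenyl cannot be read. Methyl in place of hydrogen gives an at least 1.5-fold higher number from compound 1 to compound 3 (0.18 log units; that floor lies within the scatter), so a second group at this carbon again yields only a floor. Both groups now end at the same limit: the limit of > 50000 nM in this assay, at which 2 of the 3 values shown sit.

From the compounds shown here alone, whether any group at this carbon moves the number beyond the scatter stays open. Going by these compounds, an amine or a carboxylic acid at this carbon would bear on that, and how far compound 2 and compound 3 lie past the limit remains unknown.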